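The compounds below may be only part of what the source reports. "The series", "measured", "known", "first", "only" and "open" are said of these compounds alone.

Measured in an ADME assay on RAW264.7 cells (Mus musculus) for cytotoxicity, read by MTT assay, with a stated time of 24 h; a higher number here means that more compound is tolerated, a lower number that less compound is tolerated
- compound 1 (`CC/C=C\C[C@H]1C(=O)C=C[C@H]1CC(=O)OCc1ccccc1`) gives 31 uM
- compound 2 (`CC/C=C\C[C@H]1C(=O)C=C[C@H]1CC(=O)Oc1ccc(O)cc1`) gives 49 uM
- compound 3 (`CC/C=C\C[C@H]1C(=O)C=C[C@H]1CC(=O)OCCOCCOC`) gives 161 uM

Compound 1 and compound 2 lie within the scatter of each other (a 1.6-fold higher number from compound 1 to compound 2 (0.20 log units; within the scatter)). Compound 3 stands clear of both (a 5.2-fold higher number from compound 1 to compound 3 (0.72 log units; beyond the scatter)) and (a 3.3-fold higher number from compound 2 to compound 3 (0.52 log units; beyond the scatter)).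

Compound 4 (`CC/C=C\C[C@H]1C(=O)C=C[C@H]1CC(=O)OC(C)c1ccccc1`) departs from compound 1 by a single change (methyl in place of hydrogen on a saturated chain carbon bound to an aromatic carbon and an oxygen next to a carbonyl group), methyl in place of hydrogen on a saturated chain carbon bound to an aromatic carbon and an oxygen next to a carbonyl group. For the measured compounds named here, no measured step makes this change, so the evidence is indirect. Going by the values given here, of the steps from compound 1, the one to compound 2 stayed within the scatter, while the modest one to compound 3 (a 5.2-fold higher number from compound 1 to compound 3 (0.72 log units; beyond the scatter)) replaces the phenyl, which compound 4 keeps. No step beyond the scatter is therefore expected in this assay. The expected step is small (a 1.1-fold lower number from compound 1 to compound 4 (0.04 log units; within the scatter)). For compound 4 the estimated value is 28 uM, with an expected range from 14 uM to 55 uM.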

Compound 4, half-maximal toxic concentration: 31 uM
Estimate against measurement, compound 4: 1.1-fold (0.04 log units) below, and the stated range covers the measured number.
By their numbers in this assay, from the lowest: compounds 1, 4 and 2 (each within the scatter of the next); then compound 3.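

In this assay, methyl in place of hydrogen on a saturated chain carbon bound to an aromatic carbon and an oxygen next to a carbonyl group gives no change at the digits printed from compound 1 to compound 4 (within the scatter). Unlike the steps among the earlier compounds, which exchanged the whole group on the oxygen or its phenyl, this step keeps the phenyl and reads this carbon directly. At this carbon, the added methyl leaves the number within the scatter. No measured data in the series give a reason for this result.

Going by these compounds, it remains open whether an ethyl or a longer chain at this carbon would also stay within the scatter. Also open, on these data alone, is what a carboxylic acid or an amine on the phenyl would do.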